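A few compounds are considered here, and "the series" means these few. Any claim that something is new, unique, unknown or untested is made for them only; others in the source may bear on it.

Measured so far:
compound 1, `O=C1N[C@@H](c2c[nH]c3ccccc23)CN=C1c1c[nH]c2ccccc12`: 11.5 ug/mL
compound 2, `O=C1NC[C@@H](c2c[nH]c3cc(Br)ccc23)N=C1c1c[nH]c2ccccc12`: 8.5 ug/mL

Both compounds were tested in an ADME assay on SK-OV-3 cells (Homo sapiens) for cytotoxicity; on this read-out lower numbers stand for an effect already at smaller amounts and higher numbers for an effect only at larger amounts of compound. Compound 1 gives 11.5 ug/mL, and compound 2 gives 8.5 ug/mL. Of these two numbers, compound 2 holds the smaller one, and compound 1 is the nearest to it; the gap between them falls within the usual scatter of this kind of measurement, so on this read-out the two compounds cannot be told apart. Within the data shown here, compound 1 and compound 2 also differ from each other in more than one place, so no single structural step connects them, and their two values say nothing more than that.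

Compound 3, `O=C1NC[C@@H](c2c[nH]c3ccccc23)N=C1c1c[nH]c2ccccc12`, is the next compound. It differs from compound 2 in one place: hydrogen in place of bromo on an aromatic carbon. Among the measured compounds shown here, no measured pair differs only in this way, so the numbers so far give no guide to what removing bromo does here. The expected step is a 1.3-fold higher number from compound 2 to compound 3 (0.11 log units; within the scatter), within the scatter and without a clear direction. Compound 3 is therefore estimated at 11 ug/mL, with a range from 5 ug/mL to 25 ug/mL.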

Compound 3, concentration for half-maximal effect: 12.6 ug/mL
Compound 3: middle estimate off by 1.1-fold (0.06 log units), on the low side; low and high end bracket the measured number.
By their numbers in this assay, from the lowest: compounds 2, 1 and 3 (each within the scatter of the next).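

In this assay, among these compounds, the pair compound 2 and compound 3 is the first to differ in one place only, and hydrogen in place of bromo on an aromatic carbon gives a 1.5-fold higher number from compound 2 to compound 3 (0.17 log units; within the scatter) for this pair. A single step can now be read at this position, on the six-membered aromatic ring of carbon only, and it shows that the bromo and hydrogen forms cannot be told apart on this read-out, so the one heavy atom of bromine makes no difference that can be read here. Nothing among the data offers an explanation for this result.

The compounds shown leave open whether a different group on the same aromatic carbon, such as an amine, a methoxy group or a carboxylic acid, would give a number clearly outside the scatter. They also leave open whether the other halogens, fluoro and chloro, would match bromo and hydrogen here, or whether a group on another carbon of this ring would behave in the same way.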